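Butyl-to-bromo exchange on the phenylurea series

This account rests on a few compounds, and the source may have more. Where it says the series, first, only, none or still open, it means among the compounds named here.

Measured compounds:
compound 1 `CCCCc1ccc(NC(=O)N[C@H](C)c2ccccc2)cc1`, 100%
compound 2 `CCCCc1ccc(NC(=O)N[C@@H](C)c2ccccc2)cc1`, 98%
compound 3 `CCCCCCCc1ccc(NC(=O)N[C@H](C)c2ccccc2)cc1`, 100%

In an ADME assay on the whole organism with Oryza sativa as the target, tested at 0.1 uM (a higher number here means a weaker effect of the compound at the concentration tested, a lower number a stronger effect), compound 1 gives 100%, compound 2 gives 98% and compound 3 gives 100%. Compound 2 therefore sits with the other two inside the scatter; none of the three is distinguished. The next compound, compound 4 `C[C@H](NC(=O)Nc1ccc(Br)cc1)c1ccccc1`, differs from compound 2 by bromo in place of butyl on an aromatic carbon. For the measured compounds named here, no measured step changes this part of the structure: a number 2 percentage points lower from compound 1 to compound 2 (within the scatter) concerns configuration only, and no change at the digits printed from compound 1 to compound 3 (within the scatter) lengthens the chain without moving the number. Both steps were flat, and nothing on hand points to a shift beyond the scatter for bromo in place of butyl on an aromatic carbon, so compound 4 is expected near the others, as a number 1 percentage points lower from compound 2 to compound 4 (within the scatter). The estimate for compound 4 is 97%, between 85% and 100%.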

Compound 4, a percentage reported as activity, at one concentration (the size of the read-out at that concentration, not a potency): 98%
The estimate for compound 4 lay 1 percentage points below the measured number; low and high end bracket the measured number.
By their numbers in this assay, from the lowest: compounds 2, 4, 1 and 3 (each within the scatter of the next).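

Bromo in place of butyl, on an aromatic carbon para to a large group, leaves the read-out in this assay flat: no change at the digits printed from compound 2 to compound 4 (within the scatter). The earlier steps shown here covered configuration and chain length, whereas this one replaces the butyl chain itself, and a single bromine atom serves as well as its four carbons at this concentration. Nothing on hand bears on why this exchange is flat.

From the compounds shown here alone, whether an amine or a carboxylic acid at this position would move the number remains open. So does whether any change to the shared core separates a compound from the others beyond the scatter.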